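A few compounds are considered here, and "the series" means these few. Any claim that something is new, unique, unknown or untested is made for them only; others in the source may bear on it.

Of the compounds shown here, two have been read in a functional assay on MCF7 cells (Homo sapiens) for cytotoxicity, read by MTT assay, with a stated time of 72 h; on this read-out higher numbers stand for weaker inhibition and lower numbers for stronger inhibition. Compound 1 (`CNC(=O)c1cc(Oc2ccc(NC(=O)c3cc(-c4ccc(Br)cc4)ncn3)cc2)ccn1`) gives > 100000 nM, which is a limit of the assay and not a number. Within the data shown here, compound 2 (`CCc1ccc(-c2cc(C(=O)Nc3ccc(Oc4ccnc(C(=O)NC)c4)c(F)c3)ncn2)cc1`) gives 7630 nM, the only actual number so far in this assay. Compound 3 (`CNC(=O)c1cc(Oc2ccc(NC(=O)c3cc(-c4ccc(Br)cc4)ncn3)cc2F)ccn1`) follows from compound 2 by one change, 4-ethylphenyl to 4-bromophenyl: bromo in place of ethyl on an aromatic carbon. This places bromo in place of ethyl on an aromatic carbon, para to a large group. Among the measured compounds shown here, no measured step covers this change, so the expectation is loosely founded. For the measured compounds named here, the only other guide is compound 1 at > 100000 nM, again a limit. A moderate shift towards weaker inhibition in this assay is expected, estimated as a 2.0-fold higher number from compound 2 to compound 3 (0.29 log units; within the scatter). For compound 3 the estimated value is 15000 nM, with an expected range of 4000 nM to 60000 nM.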

Compound 3, half-maximal inhibitory concentration: > 100000 nM
Compound 3 was reported as a limit; the forecaster's own chance of this, stated with the estimate: 30%; middle value at least 6.6-fold (0.82 log units) away from the limit.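

In this assay, among these compounds, exchanging 4-ethylphenyl for 4-bromophenyl gives an at least 13-fold higher number from compound 2 to compound 3 (1.11 log units; beyond the scatter), the first single change whose size can be read, and it lies beyond the scatter. Among the compounds shown, ethyl is the only group at this place on the aromatic ring that gives an actual number; both compounds with bromo there end at a limit. Compound 3 stands at a limit of the assay and not at a number, so the step gives only a minimum size: the limit of > 100000 nM in this assay, at which 2 of the 3 values shown sit.

Compound 1 and compound 3 are both limits, so the step between them cannot be read and fluoro in place of hydrogen has no readable size. Open too, from the compounds shown here alone, is whether a propyl chain, a methoxy group or an amine at this place would give a number in this assay.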